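The source may report more compounds than this note shows. Statements on the series, on what has been measured and on what is new or still open speak of the compounds shown alone.

Within the data shown here, in a functional assay on DU-145 cells (Homo sapiens) for inhibition, read by trypan blue exclusion, with a stated time of 96 h (a higher number here means a weaker inhibitor of growth, a lower number a stronger inhibitor of growth), compound 2 `Cc1ccsc1/C=C(/SCc1ccc(Cl)cc1Cl)C(=O)c1ccc(Cl)cc1` gives 10000 nM and stands lowest so far, with compound 1 `Cc1ccsc1/C=C(/SCc1ccc(Cl)cc1)C(=O)c1ccc(Cl)cc1` at 50000 nM as the only other number. Compound 3 `Cc1ccc(CS/C(=C/c2sccc2C)C(=O)c2ccc(Cl)cc2)cc1` has 4-methylphenyl in place of 2,4-dichlorophenyl on a saturated chain carbon bound to a sulfur. Among the measured compounds shown here, only one measured step bears on this, a 5.0-fold lower number from compound 1 to compound 2 (0.70 log units; beyond the scatter) (chloro in place of hydrogen on an aromatic carbon). For the measured compounds named here, compound 3 lacks that added chloro, and no measured step covers methyl. A higher number of similar, modest size is therefore expected in this assay for this change. The expected step is a 3.0-fold higher number from compound 2 to compound 3 (0.48 log units; beyond the scatter) (an estimate). For compound 3 the estimate is 30000 nM (range 10000 nM to 90000 nM).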

Compound 3, concentration for 50% growth inhibition: 10000 nM
Estimate against measurement, compound 3: 3.0-fold (0.48 log units) above; low and high end bracket the measured number.
By their numbers in this assay, from the lowest: compounds 2 and 3 (each within the scatter of the next); then compound 1.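

In this assay the change at this position gives no change at the digits printed from compound 2 to compound 3 (within the scatter), so a ring with no chloro at all can match the 2,4-dichlorophenyl compound. Methyl in place of chloro gives a 5.0-fold lower number from compound 1 to compound 3 (0.70 log units; beyond the scatter) and so shows that the lower number does not depend on adding a second chloro. Nothing available explains why these groups behave this way.

As far as these compounds go, whether the same holds for a methoxy group or an amine on this ring stays open. So does the outcome with the ring replaced by a longer chain.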